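The source may report more compounds than this note shows. Statements on the series, on what has been measured and on what is new or still open speak of the compounds shown alone.

Measured so far in a functional assay on PC-3 cells (Homo sapiens); on this read-out lower numbers stand for stronger inhibition of growth and higher numbers for weaker inhibition of growth:
- compound 1 `O=S(=O)(/C=C/c1ccc(Cl)c(Cl)c1)Cc1ccc(Nc2ncnc3ccc(Br)cc23)cc1` gives 11000 nM
- compound 2 `O=S(=O)(/C=C/c1ccc(O)cc1)Cc1ccc(Nc2ncnc3ccc(Br)cc23)cc1` gives 42000 nM

Among the measured compounds shown here, compound 2 has the higher of the two numbers, and compound 1 is its only neighbour. Compound 3 `O=S(=O)(/C=C/c1ccc(C(F)(F)F)cc1F)Cc1ccc(Nc2ncnc3ccc(Br)cc23)cc1` differs from compound 2 by this change: 2-fluoro-4-(trifluoromethyl)phenyl in place of 4-hydroxyphenyl on a double-bonded chain carbon bound to a double-bonded chain carbon (on a double-bonded chain carbon bound to a double-bonded chain carbon). For the measured compounds named here, the only measured step bearing on it is a 3.8-fold higher number from compound 1 to compound 2 (0.58 log units; beyond the scatter) and that modest step brought the 4-hydroxyphenyl in. Compound 3 loses that group again, so a step of similar size towards a lower number is expected in this assay on this single pair. The estimate expects a 3.2-fold lower number from compound 2 to compound 3 (0.51 log units; beyond the scatter) in size and direction. Compound 3 is estimated at 13000 nM (range 5000 nM to 35000 nM).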

Compound 3, concentration for 50% growth inhibition: 58000 nM
For compound 3 the middle estimate is 4.5-fold (0.65 log units) below the measured one, outside the stated range (above it).
By their numbers in this assay, from the lowest: compound 1; then compounds 2 and 3 (each within the scatter of the next).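

In this assay, 2-fluoro-4-(trifluoromethyl)phenyl in place of 4-hydroxyphenyl gives a 1.4-fold higher number from compound 2 to compound 3 (0.14 log units; within the scatter), so removing the hydroxyl group at this position does not by itself bring the number back towards that of compound 1. The same group in place of 3,4-dichlorophenyl gives a 5.3-fold higher number from compound 1 to compound 3 (0.72 log units; beyond the scatter), so halogen on this ring is not enough either, and compound 1 stands alone at the low end of the three. No supporting data bear on the reason for this.

Still open, as far as these compounds go, is how much of the edge of compound 1 depends on chlorine. A phenyl ring with a single chlorine, an amine or a carboxylic acid at this position would test that.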